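Cyclohexanone bis-arylidene series: nitrophenyl placement

The source may hold more compounds than are shown below. What is called first, only, known or untested is meant among the compounds shown, and "the series" means these compounds.

Measured so far:
Compound 1 `O=C1/C(=C/c2ccc(F)cc2)CCC/C1=C\c1ccc([N+](=O)[O-])cc1` — 17100 nM
Compound 2 `CN(C)c1ccc(/C=C2\CCC/C(=C\c3cccc([N+](=O)[O-])c3)C2=O)cc1` — 10900 nM

Both compounds were tested in a functional assay on MOLT-4 cells (Homo sapiens) for cytotoxicity, with a stated time of 72 h; on this read-out lower numbers stand for stronger inhibition and higher numbers for weaker inhibition. Compound 1 gives 17100 nM in this assay. Compound 2 gives 10900 nM in this assay, the lower of the two numbers; the gap to compound 1 lies within the scatter, so the two compounds are not told apart by these data.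

Compound 3 `CN(C)c1ccc(/C=C2\CCC/C(=C\c3ccc([N+](=O)[O-])cc3)C2=O)cc1` has not been measured. It differs from compound 2 in one place: 4-nitrophenyl in place of 3-nitrophenyl on a double-bonded chain carbon bound to a double-bonded ring carbon. Among the compounds with values here, no pair of measured compounds shows this change on its own, so its effect is not read directly from the numbers above. Compound 1, which already carries the 4-nitrophenyl, sits within the scatter of compound 2, which gives no hint of a move in either direction.

Compound 3 is therefore expected to land close to compound 2, with a step of a 1.1-fold higher number from compound 2 to compound 3 (0.04 log units; within the scatter) that stays within the scatter. The estimate for compound 3 in this assay is 12000 nM, with a range from 5000 nM to 30000 nM.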

Compound 3, half-maximal inhibitory concentration: > 500000 nM
Compound 3 gave a limit, no number; the forecaster's own chance of this, stated with the estimate: 5%; middle value at least 41-fold (1.61 log units) from the limit.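

In this assay compound 3 gives a limit of the assay and not a number: the limit of > 500000 nM in this assay, at which 1 of the 3 values shown sits.

With the dimethylamino group held in place, 4-nitrophenyl in place of 3-nitrophenyl on a double-bonded chain carbon bound to a double-bonded ring carbon gives an at least 45-fold higher number from compound 2 to compound 3 (1.66 log units; beyond the scatter), so this position is sensitive to where the nitro group sits on the phenyl ring. With 4-nitrophenyl held in place, dimethylamino in place of fluoro on an aromatic carbon gives an at least 29-fold higher number from compound 1 to compound 3 (1.46 log units; beyond the scatter), so 4-nitrophenyl alone does not bring the read-out to the limit: in these compounds that happens only where it is paired with dimethylamino.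

Both steps are bounded on one side only, and the compounds shown do not settle how 3-nitrophenyl behaves when fluoro takes the place of dimethylamino. Also open, on these data alone, is whether a primary amine or a carboxylic acid in place of the nitro group of compound 3 would return a measurable number while the dimethylamino group stays in place.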